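From Fluoro to Chloro: Expecting Little Change

The source may report more compounds than this note shows. Statements on the series, on what has been measured and on what is new or still open speak of the compounds shown alone.

Of the compounds shown here, three built on one shared core have been measured in a functional assay on MKN-45 cells (Homo sapiens) for cytotoxicity, read by MTT assay, with a stated time of 72 h; on this read-out higher numbers stand for weaker inhibition and lower numbers for stronger inhibition. Compound 1 `CN(C)CCCNc1nc(-c2ccc(NC(=O)Nc3ccc(Cl)cc3)cc2)nc2c(Cl)c(Cl)sc12` gives 1530 nM, compound 2 `CN(C)CCNc1nc(-c2ccc(NC(=O)Nc3ccc(Cl)cc3)cc2)nc2c(Cl)c(Cl)sc12` gives 910 nM, and compound 3 `CCN(CC)CCNc1nc(-c2ccc(NC(=O)Nc3ccc(F)cc3)cc2)nc2c(Cl)c(Cl)sc12` gives 1370 nM. Compound 3 stands second highest of the three numbers; the number of compound 1 sits closest to it and the number of compound 2 furthest away, yet each of these gaps lies within the scatter, so the three cannot be put in any order. Going by the values given here, the one step between measured compounds, a 1.7-fold lower number from compound 1 to compound 2 (0.23 log units; within the scatter), concerns the chain and is itself within the scatter.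

Compound 4 `CCN(CC)CCNc1nc(-c2ccc(NC(=O)Nc3ccc(Cl)cc3)cc2)nc2c(Cl)c(Cl)sc12` is not yet measured. It differs from compound 3 by chloro in place of fluoro on an aromatic carbon. Among the compounds with values here, no measured step touches this kind of change, so the data give no guide to its direction or size. With nothing pointing either way, and the whole set spanning less than the scatter, the estimated step is a 1.1-fold lower number from compound 3 to compound 4 (0.02 log units; within the scatter) in this assay. Compound 4 is therefore expected to give 1300 nM, with a range from 600 nM to 2800 nM.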

Compound 4, half-maximal inhibitory concentration: 890 nM
The estimate for compound 4 lay 1.5-fold (0.16 log units) above the measured number; low and high end bracket the measured number.
By their numbers in this assay, from the lowest: compounds 4, 2, 3 and 1 (each within the scatter of the next).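

Chloro in place of fluoro on an aromatic carbon, para to a large group, gives a 1.5-fold lower number from compound 3 to compound 4 (0.19 log units; within the scatter) in this assay and so offers the first reading of this change: at this position, with this chain, the swap stays inside the scatter. The chain end shows the same picture, with a 1.0-fold lower number from compound 2 to compound 4 (0.01 log units; within the scatter) for diethylamino in place of dimethylamino and a 1.7-fold lower number from compound 1 to compound 4 (0.24 log units; within the scatter) for diethylamino in place of (dimethylamino)methyl, so compound 4 cannot be separated from any of the other three. No measurement is at hand that would explain these results.

Going by these compounds, whether a larger group at this position, such as bromo or trifluoromethyl, would shift the number beyond the scatter remains open. So does the effect of a cyclic amine such as morpholine at the chain end.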